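A few compounds are considered here, and "the series" means these few. Any claim that something is new, unique, unknown or untested is made for them only; others in the source may bear on it.

Within the data shown here, in an assay on cells for activation of Cystic fibrosis transmembrane conductance regulator (Homo sapiens), read by fluorescence, with a stated time of 10 min (on this read-out lower numbers stand for an effect already at smaller amounts and higher numbers for an effect only at larger amounts of compound), compound 1 `O=c1c(-c2cccc([N+](=O)[O-])c2)nc2ccccc2n1Cc1ccccc1` gives 9 nM, while compound 2 `CCn1c(=O)c(-c2cccc([N+](=O)[O-])c2)nc2ccccc21` gives 65 nM, the higher of the two numbers known so far. Among the measured compounds shown here, the only measured step at this place is a 7.2-fold higher number from compound 1 to compound 2 (0.86 log units; beyond the scatter). Compound 3 `C=CCn1c(=O)c(-c2cccc([N+](=O)[O-])c2)nc2ccccc21` differs from compound 2 by vinyl in place of methyl on a saturated chain carbon bound to an aromatic nitrogen. For the measured compounds named here, with a single modest step as guide, a change no larger than that step, and pointing toward lower numbers, is expected for compound 3. For compound 3 the estimated value is 35 nM, with a range from 12 nM to 110 nM. That estimate for compound 3 means an expected step of a 1.9-fold lower number from compound 2 to compound 3 (0.27 log units; within the scatter).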

Compound 3, half-maximal effective concentration: 55 nM
Compound 3: the middle estimate sits 1.6-fold (0.20 log units) below what was measured, within the range that was stated.
By their numbers in this assay, from the lowest: compound 1; then compounds 3 and 2 (each within the scatter of the next).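

In this assay, ethyl to allyl at this place barely matters, with a 1.2-fold lower number from compound 2 to compound 3 (0.07 log units; within the scatter), so the added vinyl does not separate compound 3 from compound 2. The phenyl remains what sets compound 1 apart, with a 6.1-fold higher number from compound 1 to compound 3 (0.79 log units; beyond the scatter), so a vinyl in its place does not reproduce the phenyl's result. Nothing available explains this difference. Going by these compounds, what stays open is whether a longer saturated chain, a cyclohexyl or an amine at this place would fall with the small groups or with the phenyl.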